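Amide versus sulfonamide on the shared core

A few compounds are considered here, and "the series" means these few. Any claim that something is new, unique, unknown or untested is made for them only; others in the source may bear on it.

For the measured compounds named here, compound 3 `CNc1nc(NCc2ccc(NS(=O)(=O)c3ccc(C)cc3)cc2)c2ccccc2n1` gives 4900 nM in a functional assay on SW480 cells (Homo sapiens) for inhibition, read by luminescence and resazurin assay, with a stated time of 3 days (a lower number here means a stronger inhibitor, a higher number a weaker inhibitor), the highest of the two numbers known, the nearest being compound 2 `CNc1nc(NCc2ccc(NC(=O)c3ccc(F)cc3)cc2)c2ccccc2n1` at 2000 nM. Compound 1 `CN1CCN(c2nc(NCc3ccc(NC(=O)c4ccncc4)cc3)c3ccccc3n2)CC1` returns only the limit > 20000 nM in this assay, not a number. The move to compound 4 `CNc1nc(NCc2ccc(NC(=O)c3ccncc3)cc2)c2ccccc2n1` is (pyridin-4-yl)carbonyl in place of (4-methylphenyl)sulfonyl on a nitrogen on an aromatic ring. Going by the values given here, the one measured step that bears on it, a 2.5-fold higher number from compound 2 to compound 3 (0.39 log units; beyond the scatter), runs in the opposite sense: replacing an arylcarbonyl by an arylsulfonyl on that nitrogen weakened inhibition modestly. Returning to an arylcarbonyl is therefore expected to lower the number modestly, a 2.0-fold lower number from compound 3 to compound 4 (0.29 log units; within the scatter); whether the pyridine ring shifts it further from compound 2 cannot be told from compound 1, which sits at a limit. Compound 4 is estimated at 2500 nM, with a range of 800 nM to 8000 nM.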

Compound 4, half-maximal inhibitory concentration: > 20000 nM
Compound 4 was reported as a limit; the forecaster's own chance of this, stated with the estimate: 10%; middle value at least 8.0-fold (0.90 log units) away from the limit.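

In this assay, keeping the carbonyl and changing only the ring gives an at least 10-fold higher number from compound 2 to compound 4 (1.00 log units; beyond the scatter), so on this series the pyridin-4-yl group, not the amide link alone, separates the two amides. The change from the sulfonyl compound gives an at least 4.0-fold higher number from compound 3 to compound 4 (0.61 log units; beyond the scatter), so an arylcarbonyl on this nitrogen does not by itself outperform (4-methylphenyl)sulfonyl. Compound 4 is a limit, not a number, so both steps give only a minimum size: the limit of > 20000 nM in this assay, at which 2 of the 4 values shown sit.

The step between the two limit compounds cannot be read. Open, on these data alone, is whether a plain phenyl or a 4-methoxyphenyl on the carbonyl stays nearer compound 2 or falls to the limit.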